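A few compounds are considered here, and "the series" means these few. Any claim that something is new, unique, unknown or untested is made for them only; others in the source may bear on it.

Compound 1 `Clc1cc(Cl)cc(CNC2CCCC(c3nc4nc(Cl)ccc4[nH]3)C2)c1`: 33100 nM
Compound 2 `Clc1cc(Cl)cc(CNC2CCCN(c3nc4nc(Cl)ccc4[nH]3)C2)c1`: 46200 nM

Both compounds were tested in a toxicity assay on CRL-1855 cells (Homo sapiens) for cytotoxicity, read by resazurin assay, with a stated time of 48 h; a higher number here means that more compound is needed for the effect, a lower number that less compound is needed. Among the measured compounds shown here, the numbers of compound 1 and compound 2 lie within the usual scatter of each other, so compound 2 stands level with the only other measured compound.

Compound 3 `Clc1cc(Cl)cc(CN[C@H]2CCCN(c3nc4nc(Cl)ccc4[nH]3)C2)c1` has the same atoms and bonds as compound 2: the two compounds have the same atoms and bonds; at least one stereo element is drawn with a configuration in one of them and without one in the other: 1 of 1 stereo elements differ; a stereocentre at a saturated ring carbon is drawn without a configuration in compound 2 and S in compound 3. For the measured compounds named here, no measured pair shows what such a change does, so no shift beyond the scatter is expected in this assay, in either direction. The expected change is a 1.1-fold lower number from compound 2 to compound 3 (0.04 log units; within the scatter). Compound 3 is estimated at 42000 nM, with a likely range of 22000 nM to 80000 nM.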

Compound 3, half-maximal effective concentration: 29300 nM
Beside the measured number, compound 3's estimate is 1.4-fold (0.16 log units) above it; the range from low to high includes it.
By their numbers in this assay, from the lowest: compounds 3, 1 and 2 (each within the scatter of the next).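

Among the compounds shown here, this is the first measured pair to isolate a stereocentre at a saturated ring carbon, and in this assay it gives a 1.6-fold lower number from compound 2 to compound 3 (0.20 log units; within the scatter). Drawing this centre as S therefore leaves compound 3 level with compound 2, so no effect of this change can be read from the pair. The comparison rests on one structural difference: the fact that one of compounds 2 and 3 is drawn with a defined configuration and the other without, at the place where they differ

Going by these compounds, it remains open how the R configuration at this carbon would read in this assay. Also open, on these data alone, is whether an amide in place of the secondary amine would give a different number.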